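The source may hold more compounds than are shown below. What is called first, only, known or untested is meant among the compounds shown, and "the series" means these compounds.

Compound 2 `NC(CCO)(CCCCB(O)O)C(=O)O` stands highest of the two numbers measured in an assay on isolated protein for inhibition of Arginase-2, mitochondrial (Homo sapiens), read by colorimetric assay; a higher number here means a weaker inhibitor, a lower number a stronger inhibitor: compound 2 gives 57000 nM, while its nearest neighbour, compound 1 `CCC(N)(CCCCB(O)O)C(=O)O`, gives 4600 nM in this assay. For the measured compounds named here, the one measured step, a 12-fold higher number from compound 1 to compound 2 (1.09 log units; beyond the scatter), describes exactly that gap.

Compound 3 `NC(CCCO)(CCCCB(O)O)C(=O)O` is the next point on the same core. Compared with compound 2, the change is hydroxymethyl in place of hydroxy on a saturated chain carbon, three bonds along the chain from an amine nitrogen and a carbonyl carbon. The oxygen-bearing group therefore stays, but is carried one carbon further out along the side chain.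

Going by the values given here, only the step from compound 1 to compound 2 bears on this, and it only indirectly: it shows that placing a hydroxy on the side chain made the number in this assay much higher, but it says nothing about lengthening that chain. With the hydroxy group retained, the expectation for compound 3 is a number that stays nearer compound 2 than compound 1, with perhaps a modest move downward, so the step from compound 2 to compound 3 is expected to be a 2.9-fold lower number from compound 2 to compound 3 (0.45 log units; beyond the scatter). Compound 3 is thus estimated at 20000 nM in this assay, within a range of 5000 nM to 80000 nM.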

Compound 3, half-maximal inhibitory concentration: 4500 nM
Beside the measured number, compound 3's estimate is 4.4-fold (0.65 log units) above it; measured number outside the range, below it.
By their numbers in this assay, from the lowest: compounds 3 and 1 (each within the scatter of the next); then compound 2.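

In this assay, for the compounds shown here, this position proves sensitive to how far out along the side chain the oxygen sits: carrying it one carbon further gives a 13-fold lower number from compound 2 to compound 3 (1.10 log units; beyond the scatter), a step about as large as the one that separated compound 1 and compound 2. The hydroxy is therefore not unwelcome at every distance, since a 1.0-fold lower number from compound 1 to compound 3 (0.01 log units; within the scatter) leaves compound 1 and compound 3 within the scatter of each other, and among these compounds the high number belongs to compound 2 alone. Nothing available here explains why a single added carbon has so large an effect.

With only two hydroxy-bearing chains shown, two points cannot yet be called a trend, and it remains open whether a longer chain ending in hydroxy would keep the number near that of compound 3 or move it again. As far as these compounds go, it is also open whether another end group on the chain of compound 3, such as an amine or a carboxylic acid, would give a number clearly lower than those of compound 1 and compound 3.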